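The source may report more compounds than this note shows. Statements on the series, on what has been measured and on what is new or still open speak of the compounds shown alone.

Compound 1 `Cc1cccc(Cn2cc(COc3ccc4c(=O)ccoc4c3)nn2)c1`: 22400 nM in a functional assay on QGY7701 cells (Homo sapiens) for cytotoxicity, read by MTT assay, with a stated time of 48 h; on this read-out higher numbers stand for weaker inhibition and lower numbers for stronger inhibition. Compound 2 `O=c1ccoc2cc(OCc3cn(Cc4ccc(Br)cc4)nn3)ccc12`: 96400 nM in this assay.

Compound 2 has the higher of these two numbers; the step of a 4.3-fold higher number from compound 1 to compound 2 (0.63 log units; beyond the scatter) sets it apart from compound 1. Compound 3 `O=c1ccoc2cc(OCc3cn(Cc4ccccc4F)nn3)ccc12` differs from compound 2 by 2-fluorophenyl in place of 4-bromophenyl on a saturated chain carbon bound to an aromatic nitrogen. Going by the values given here, only that one step bears on this change, and it was modest, so a step of comparable size is expected in this assay, more likely downward than upward. Compound 3 is estimated at 45000 nM, within 15000 nM to 135000 nM, which would be a step of a 2.1-fold lower number from compound 2 to compound 3 (0.33 log units; beyond the scatter).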

Compound 3, half-maximal inhibitory concentration: 36900 nM
For compound 3 the middle estimate is 1.2-fold (0.09 log units) above the measured one, within the range that was stated.
By their numbers in this assay, from the lowest: compounds 1 and 3 (each within the scatter of the next); then compound 2.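

Changing 4-bromophenyl to 2-fluorophenyl on a saturated chain carbon bound to an aromatic nitrogen gives a 2.6-fold lower number from compound 2 to compound 3 (0.42 log units; beyond the scatter) in this assay, so compound 2 now stands apart from two other substituted phenyl groups at this place. By contrast, the 2-fluorophenyl and 3-methylphenyl groups are not told apart, with a 1.6-fold higher number from compound 1 to compound 3 (0.22 log units; within the scatter). No evidence is available that accounts for these results.

The halogen and its place on the ring change together in this step, so their contributions cannot be separated. On these data alone, how a phenyl group carrying an amine or a carboxylic acid would read at this place stays open.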